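Benzamido replacing the fluorophenyl carbamoyl on the shared core

This account rests on a few compounds, and the source may have more. Where it says the series, first, only, none or still open, it means among the compounds named here.

Within the data shown here, compound 1 `Cc1cc(C(=O)Nc2ccc(F)cc2)nn1Cc1cc(Cl)ccc1OCc1ccccc1` is the only member of the series with a number in a physicochemical assay for lipophilicity, at pH 7.4; on this read-out lower numbers stand for lower lipophilicity and higher numbers for higher lipophilicity: there compound 1 gives 3. Compound 2 `CC(=O)Nc1cc(C)n(Cc2cc(Cl)ccc2OCc2ccccc2)n1` reaches only a limit, giving > 3.7. Compound 3 `Cc1cc(NC(=O)C2CCOC2)nn1Cc1cc(Cl)ccc1OCc1ccccc1` likewise reaches a limit, giving > 3.7. Compound 4 `Cc1cc(NC(=O)c2ccccc2)nn1Cc1cc(Cl)ccc1OCc1ccccc1` differs from compound 1 by benzamido in place of (4-fluorophenyl)carbamoyl on an aromatic carbon. Among the measured compounds shown here, two measured steps bear on this change, both at the same aromatic carbon: a number at least 0.70 log units higher from compound 1 to compound 2 (beyond the scatter) and a number at least 0.70 log units higher from compound 1 to compound 3 (beyond the scatter). Because both of these ended at the limit of > 3.7 in this assay, at which 2 of the 3 values shown sit, a rise beyond the scatter is expected for compound 4 as well, most likely again reaching the limit. Compound 4 is therefore estimated at 3.9, in the range 3.4 to 4.4, an expected step of a number 0.90 log units higher from compound 1 to compound 4 (beyond the scatter).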

Compound 4, distribution coefficient: > 3.7
Compound 4: a limit, no number; the forecaster's own chance of this, stated with the estimate: 60%; the middle value lies beyond the limit too.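

In this assay, benzamido gives a number at least 0.70 log units higher from compound 1 to compound 4 (beyond the scatter), although it keeps the six-membered aromatic ring that acetamido and ((oxolan-3-yl)carbonyl)amino lack. Loss of that ring is therefore not required for this step, and methyl, oxolan-3-yl and phenyl on the carbonyl carbon all go with a limit rather than a number. The steps among compounds 2, 3 and 4 cannot be read, so these compounds cannot be ranked: the limit of > 3.7 in this assay, at which 3 of the 4 values shown sit.

Open, as far as these compounds go, is whether 4-fluorobenzamido or an amine on this aromatic carbon would give a number rather than a limit in this assay.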